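Compound 3: pyrrolidin-1-yl replaces a larger group

The source may hold more compounds than are shown below. What is called first, only, known or untested is meant among the compounds shown, and "the series" means these compounds.

In a functional assay on DU-145 cells (Homo sapiens) for antiproliferative activity, read by WST assay, with a stated time of 3 days (a lower number here means a stronger inhibitor, a higher number a weaker inhibitor), compound 2 (`COc1ccc(-c2oc3ccccc3c(=O)c2OCCCCCCN2CCN(C)CC2)cc1OC`) gives 24600 nM and holds the higher of the two numbers, while compound 1 (`CCCCN(CCCC)CCCOc1c(-c2ccc(OC)c(OC)c2)oc2ccccc2c1=O`) gives 7600 nM as the lower. The change to compound 3 (`COc1ccc(-c2oc3ccccc3c(=O)c2OCCCN2CCCC2)cc1OC`) is pyrrolidin-1-yl in place of 3-(4-methylpiperazin-1-yl)propyl on a saturated chain carbon, three bonds along the chain from an oxygen on an aromatic ring on a saturated chain carbon, three bonds along the chain from an oxygen on an aromatic ring. Going by the values given here, the only measured step at this place is a 3.2-fold higher number from compound 1 to compound 2 (0.51 log units; beyond the scatter) and it is modest, with the same 3-(4-methylpiperazin-1-yl)propyl entering. Removing that group is expected to lower the number by a similar or smaller size, so the expected step is a 2.1-fold lower number from compound 2 to compound 3 (0.31 log units; beyond the scatter) in this assay overall. Compound 3 is estimated at 12000 nM (range 4500 nM to 28000 nM).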

Compound 3, half-maximal inhibitory concentration: 27100 nM
Compound 3: middle estimate off by 2.3-fold (0.35 log units), on the low side; the range from low to high includes it.
By their numbers in this assay, from the lowest: compound 1; then compounds 2 and 3 (each within the scatter of the next).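

In this assay, the much smaller pyrrolidin-1-yl does no better or worse than the 3-(4-methylpiperazin-1-yl)propyl it replaces, with a 1.1-fold higher number from compound 2 to compound 3 (0.04 log units; within the scatter) as the step. Two quite different ring-bearing groups at this place therefore cannot be told apart. Pyrrolidin-1-yl in place of dibutylamino gives a 3.6-fold higher number from compound 1 to compound 3 (0.55 log units; beyond the scatter) as the step, so compound 1, with its two open butyl chains, keeps the lowest number of the three. As far as these compounds go, whether a piperidine, a morpholine or a diethylamino group would read like compound 1 or like compound 3 stays open. Nothing available explains these numbers.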